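This account rests on a few compounds, and the source may have more. Where it says the series, first, only, none or still open, it means among the compounds named here.

Compound 1: `Clc1ccc(C(/C=C/c2ccccc2)=N\Nc2nncc3ccccc23)cc1`, 7.4 nM
Compound 2: `NC(=S)NNc1nncc2ccccc12`, 94 nM
Compound 3: `Cc1cc(NS(=O)(=O)c2ccc(Nc3nncc4ccccc34)cc2)no1`, 68 nM

Of the compounds shown here, three have been measured in a functional assay on HL-60 cells (Homo sapiens) for antiproliferative activity, read by sulforhodamine B assay, with a stated time of 72 h; on this read-out lower numbers stand for stronger inhibition and higher numbers for weaker inhibition. Compound 3 gives the second highest of the three numbers; its value lies within the scatter of that of compound 2, while compound 1 sits beyond the scatter at a clearly lower number. Compound 4, `O=S(=O)(Nc1nccs1)c1ccc(Nc2nncc3ccccc23)cc1`, has not been measured yet. It differs from compound 3 in one place: 1,3-thiazol-2-yl in place of 5-methyl-1,2-oxazol-3-yl on a sulfonamide nitrogen. Going by the values given here, no measured pair shows this change, so its effect is unknown; the entering group is again a five-membered aromatic ring with two hetero atoms on the sulfonamide nitrogen. The account expects a step of a 1.1-fold lower number from compound 3 to compound 4 (0.05 log units; within the scatter), not beyond the scatter. Compound 4 is therefore estimated at 60 nM, within a range from 25 nM to 150 nM.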

Compound 4, half-maximal inhibitory concentration: 77 nM
Estimate against measurement, compound 4: 1.3-fold (0.11 log units) below; measured number inside the range.
By their numbers in this assay, from the lowest: compound 1; then compounds 3, 4 and 2 (each within the scatter of the next).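

In this assay, going by these compounds alone, the exchange of 5-methyl-1,2-oxazol-3-yl for 1,3-thiazol-2-yl on a sulfonamide nitrogen gives a 1.1-fold higher number from compound 3 to compound 4 (0.05 log units; within the scatter) and is the first one-place comparison at this position. It shows that one five-membered aromatic ring can stand in for another here without a step beyond the scatter, although this single pair sets no wider pattern. Nothing shown bears on why the two rings read alike.

Still open, going by these compounds, is how a pyridin-2-yl ring or a plain methyl group would read on that nitrogen. The same applies to a sulfonamide nitrogen carrying only hydrogen.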